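The source may report more compounds than this note shows. Statements on the series, on what has been measured and on what is new or still open speak of the compounds shown alone.

In an assay for inhibition of Polyunsaturated fatty acid lipoxygenase ALOX15 (Homo sapiens), with a stated time of 8 min (on this read-out higher numbers stand for weaker inhibition and lower numbers for stronger inhibition), compound 1 `CCOC(=O)c1[nH]c2cc(Cl)ccc2c1/C=N/NC(=O)CCc1ccccc1` gives only a limit, > 10000 nM, and no number. Compound 2 `CCOC(=O)c1[nH]c2cc(Cl)ccc2c1/C=N/NC(=O)Cc1cccs1` likewise reaches only a limit in this assay, > 10000 nM. The step between them, a step that the two limits leave unreadable from compound 1 to compound 2, cannot be read; both of its ends are limits. Going by the values given here, compound 2 therefore stands at the limit alongside compound 1, and the only evidence on the measured steps is the limit of > 10000 nM in this assay, at which 2 of the 2 values shown sit.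

Compound 3 `CCOC(=O)c1[nH]c2cc(Cl)ccc2c1/C=N/NC(=O)CCC(C)C` differs from compound 2 by a single change: isobutyl in place of thiophen-2-yl on a saturated chain carbon bound to a carbonyl carbon. No measured step bears on this change: the one step shown, from compound 1 to compound 2, is unreadable, and no other compound carrying an isobutyl group at that position has been measured. Nothing in the two limits points either way. The expected step is accordingly put at a step that the limit leaves unreadable from compound 2 to compound 3, that is, no movement beyond the scatter, with the read-out most likely again a limit rather than a number. Compound 3 is therefore estimated at 15000 nM in this assay, with a range from 4000 nM to 60000 nM.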

Compound 3, half-maximal inhibitory concentration: > 10000 nM
Compound 3 gave a limit, no number; the forecaster's own chance of this, stated with the estimate: 80%; the middle value does not contradict the limit.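

Going by these compounds alone, compound 3, like compound 1 and compound 2, gives only a limit in this assay, so the steps linking compound 3 to compound 1 and to compound 2 cannot be read and no new step emerges. The compounds shown leave open whether any of these chain changes alters inhibition at all, and by how much, because the read-outs offer only this: the limit of > 10000 nM in this assay, at which 3 of the 3 values shown sit.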